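A few compounds are considered here, and "the series" means these few. Any claim that something is new, unique, unknown or untested is made for them only; others in the source may bear on it.

The three measured compounds share one core that carries two phenyl groups, and they differ in the chain that ends in the carbonyl-bearing group. Compound 1, `COC(=O)COc1cccc(-n2cnc(-c3ccccc3)c2-c2ccccc2)c1`, gives 6500 nM in an assay on H4 cells for inhibition of Fatty-acid amide hydrolase 1 (Homo sapiens); on this read-out higher numbers stand for weaker inhibition and lower numbers for stronger inhibition. Among the compounds with values here, compound 2, `CCOC(=O)CCCOc1cccc(-n2cnc(-c3ccccc3)c2-c2ccccc2)c1`, gives 91 nM in this assay, and the one step recorded between measured compounds, a 71-fold lower number from compound 1 to compound 2 (1.85 log units; beyond the scatter), is a large one. Within the data shown here, compound 3, `CCOC(=O)CCCCCCn1c(CC)nc(-c2ccccc2)c1-c1ccccc1`, gives 11 nM in this assay and stands at the lowest number of the three; the values of compound 2 and of compound 1 both lie above it beyond the scatter, though no single-point step links either of them to compound 3.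

Compound 4, `CCc1nc(-c2ccccc2)c(-c2ccccc2)n1CCCCCCCC(=O)OC`, has not yet been measured. It differs from compound 3 by (methoxycarbonyl)methyl in place of ethoxycarbonyl on a saturated chain carbon, six bonds along the chain from an aromatic nitrogen, so the two contain the same atoms joined differently, with the carbonyl one carbon further out along the chain. Among the measured compounds shown here, the only step that bears on this is the one from compound 1 to compound 2, which also lengthened the chain before the carbonyl and brought a large fall in the number, but that change sat on an oxygen on an aromatic ring and added atoms rather than rearranging them. A smaller effect, if any, is therefore expected here. The estimate for compound 4 is 9 nM, with a range from 3 nM to 30 nM, meaning an expected step of a 1.2-fold lower number from compound 3 to compound 4 (0.09 log units; within the scatter), within or just at the edge of the scatter.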

Compound 4, half-maximal inhibitory concentration: 31 nM
Estimate against measurement, compound 4: 3.4-fold (0.54 log units) below; measured number above the stated range.
By their numbers in this assay, from the lowest: compound 3; then compound 4; then compound 2; then compound 1.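

In this assay, the step at this position gives a 2.8-fold higher number from compound 3 to compound 4 (0.45 log units; beyond the scatter): on a saturated chain carbon, six bonds along the chain from an aromatic nitrogen, exchanging ethoxycarbonyl for (methoxycarbonyl)methyl changes the number beyond the scatter, although the two compounds contain the same atoms. The earlier step, a 71-fold lower number from compound 1 to compound 2 (1.85 log units; beyond the scatter), also placed the carbonyl further out along a chain, but there the number fell, while here it rises, so the direction seen at the chain on an oxygen on an aromatic ring does not carry over to this position, and these two steps go against any single rule about carbonyl placement. Nothing available here accounts for the rise.

This step moves the carbonyl and shortens the end of the ester at the same time, and the compounds shown do not separate the two changes, which a compound with (ethoxycarbonyl)methyl at this place would begin to do. Going by these compounds, how a carboxylic acid, a primary amide or a longer chain at this place would read also remains open.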